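The compounds below may be only part of what the source reports. "The series", "measured", "known", "first", "only" and "open" are said of these compounds alone.

Going by the values given here, in a functional assay on brain (Rattus norvegicus, strain Wistar) for inhibition (on this read-out lower numbers stand for stronger inhibition and higher numbers for weaker inhibition), compound 2 (`Cc1[nH]c(=O)n(C2CCCCC2)c1-c1ccc(OC(C)C)cc1`) gives 13000 nM, the lower of the two numbers so far, while compound 1 (`CCCCc1ccc(-c2c(C)[nH]c(=O)n2C2CCCCC2)cc1`) gives 27100 nM. Compound 3 (`Cc1[nH]c(=O)n(C2CCCCC2)c1-c1ccc(CC(C)C)cc1`) keeps the shared core and changes one group: isobutyl in place of isopropoxy on an aromatic carbon. This places isobutyl in place of isopropoxy on an aromatic carbon, para to a large group. Among the compounds with values here, only one measured step bears on this change: a 2.1-fold lower number from compound 1 to compound 2 (0.32 log units; beyond the scatter), with isopropoxy in place of butyl on an aromatic carbon. Compound 3 returns to an alkyl group, although isobutyl is not butyl and no branched alkyl group has been measured. On that single modest step, a shift toward a higher number in this assay is expected, but probably none beyond the scatter. The expected change is a 1.5-fold higher number from compound 2 to compound 3 (0.19 log units; within the scatter). For compound 3 the estimated value is 20000 nM, with an expected range of 8000 nM to 45000 nM.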

Compound 3, half-maximal inhibitory concentration: 10900 nM
The estimate for compound 3 lay 1.8-fold (0.26 log units) above the measured number, and the stated range covers the measured number.
By their numbers in this assay, from the lowest: compounds 3 and 2 (each within the scatter of the next); then compound 1.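

In this assay, isobutyl in place of isopropoxy, para to a large group, gives a 1.2-fold lower number from compound 2 to compound 3 (0.08 log units; within the scatter), so removing the oxygen and the one hydrogen-bond acceptor counted for isopropoxy leaves no change that can be read at this position. The branched alkyl group also gives a 2.5-fold lower number from compound 1 to compound 3 (0.40 log units; beyond the scatter), which shows that a modest shift from the butyl compound can occur with no oxygen in the group, something the step to the isopropoxy compound alone could not separate. Nothing available gives a reason for either step.

Still open, going by these compounds, is how this position responds to a group of a different kind, such as an amine or a carboxylic acid. Also open, on these data alone, is whether a chain longer than butyl, or a shorter branched one such as isopropyl, would move the number beyond the scatter.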